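Methoxycarbonyl to benzyloxycarbonyl on compound 3

This account rests on a few compounds, and the source may have more. Where it says the series, first, only, none or still open, it means among the compounds named here.

In a functional assay on HepG2 cells (Homo sapiens) for antiproliferative activity, read by MTT assay, with a stated time of 48 h (a lower number here means a stronger inhibitor of growth, a higher number a weaker inhibitor of growth), compound 1 `COC(=O)N1N=C(c2cccc(OC)c2)CC1c1cc(OC)c(OC)c(OC)c1` gives 1870 nM, compound 2 `COC(=O)N1N=C(c2ccc(OC)cc2)CC1c1cc(OC)c(OC)c(OC)c1` gives 1710 nM and compound 3 `COC(=O)N1N=C(c2cccc(O)c2)CC1c1cc(OC)c(OC)c(OC)c1` gives 650 nM. Compound 3 thus holds the lowest number of the three. Compound 4 `COc1cc(C2CC(c3cccc(O)c3)=NN2C(=O)OCc2ccccc2)cc(OC)c1OC` keeps the 3-hydroxyphenyl of compound 3 and differs in one place: phenyl in place of hydrogen on a saturated chain carbon bound to an oxygen next to a carbonyl group. This is phenyl in place of hydrogen on a saturated chain carbon bound to an oxygen next to a carbonyl group, or methoxycarbonyl to benzyloxycarbonyl. The measured steps all concern the aromatic ring on the carbon with a double bond to nitrogen: a 1.1-fold lower number from compound 1 to compound 2 (0.04 log units; within the scatter), a 2.9-fold lower number from compound 1 to compound 3 (0.46 log units; beyond the scatter) and a 2.6-fold lower number from compound 2 to compound 3 (0.42 log units; beyond the scatter). None of them touches the methoxycarbonyl, so the series offers no direct measure of this change, in size or in direction. Without such evidence, no shift beyond the scatter is expected in this assay, though the uncertainty is wide. The expected step is a 1.1-fold higher number from compound 3 to compound 4 (0.03 log units; within the scatter). For compound 4 the estimate is 700 nM, with an expected range of 200 nM to 2500 nM.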

Compound 4, concentration for 50% growth inhibition: > 10000 nM
Compound 4 was reported as a limit (the forecaster's own chance of this, stated with the estimate: 5%); middle value at least 14-fold (1.15 log units) from the limit.
By their numbers in this assay, from the lowest: compound 3; then compounds 2 and 1 (each within the scatter of the next). At a limit, above all of these: compound 4.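

Among these compounds, until now only the aromatic ring on the carbon with a double bond to nitrogen had varied; the methoxycarbonyl is the first other site to be changed, and it proves the more sensitive of the two. In this assay, methoxycarbonyl to benzyloxycarbonyl gives an at least 15-fold higher number from compound 3 to compound 4 (1.18 log units; beyond the scatter), a larger step than any among compound 1, compound 2 and compound 3, and the 3-hydroxyphenyl of compound 3 does not preserve growth inhibition once the benzyl is present. The entry for compound 4 is a limit of the assay and not a number: the limit of > 10000 nM in this assay, at which 1 of the 4 values shown sits.

From the compounds shown here alone, it remains open whether the phenyl itself or simply the greater length sets this step, a question that an ethyl or a longer saturated chain in place of the methyl would address. Also open, going by these compounds, is how an amine in place of the oxygen next to the carbonyl group would read in this assay.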